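The compounds below may be only part of what the source reports. "The series", "measured", "known", "first", "only" and "open" are said of these compounds alone.

Working notes on the series. Compound 1 `COc1ccc2nc3c(cc2c1)c(=O)c1cccc2c1n3[C@H]1NCC[C@@]21CCO` gives 850 nM in a functional assay on NCI-H460 cells (Homo sapiens) for inhibition, read by trypan blue exclusion, with a stated time of 72 h; a higher number here means a weaker inhibitor of growth, a lower number a stronger inhibitor of growth. For the measured compounds named here, compound 2 `C=CC[C@@]12CCN(C(=O)OC(C)(C)C)[C@@H]1n1c3nc4ccc(O)cc4cc3c(=O)c3cccc2c31` gives 32700 nM, and compound 3 `CC(C)(C)OC(=O)N1CC[C@@]2(CCO)c3cccc4c(=O)c5cc6cc(O)ccc6nc5n(c34)[C@@H]12` gives 26800 nM; the one measured single-point change, a 1.2-fold lower number from compound 2 to compound 3 (0.09 log units; within the scatter), is within the scatter. Compound 3 therefore stands second highest of the three numbers, close to compound 2 and far from compound 1, which differs from it in several places at once, so the two values show only that gap and not what any one change does.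

Compound 4 `CN(C)Cc1c(O)ccc2nc3c(cc12)c(=O)c1cccc2c1n3[C@H]1N(C(=O)OC(C)(C)C)CC[C@@]21CCO` differs from compound 3 by (dimethylamino)methyl in place of hydrogen on an aromatic carbon. Going by the values given here, no measured step in this set touches that position or that group; the only measured step concerns the chain on the saturated ring carbon and was within the scatter. Nothing here supports a step in either direction beyond the scatter, and the range must stay wide. For compound 4 the expected value in this assay is 20000 nM, between 5000 nM and 80000 nM, which means an expected step of a 1.3-fold lower number from compound 3 to compound 4 (0.13 log units; within the scatter).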

Compound 4, concentration for 50% growth inhibition: 16400 nM
Beside the measured number, compound 4's estimate is 1.2-fold (0.09 log units) above it; the measured number falls inside the stated range.
By their numbers in this assay, from the lowest: compound 1; then compounds 4, 3 and 2 (each within the scatter of the next).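

In this assay, (dimethylamino)methyl in place of hydrogen on an aromatic carbon, ortho to a hydroxy group and ortho to a fused ring, gives a 1.6-fold lower number from compound 3 to compound 4 (0.21 log units; within the scatter). The earlier measured step concerned only the chain on the saturated ring carbon, whereas this one shows that the aromatic position can carry this group of 4 heavy atoms without a step beyond the scatter. No separate measurement bears on this result.

As far as these compounds go, it remains open whether a carboxylic acid, a longer aminoalkyl chain or a primary amine on this aromatic carbon would give a step beyond the scatter. From the compounds shown here alone, it is also open what (dimethylamino)methyl at this position would do on the core of compound 1.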